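Chain extension from compound 1: an expectation for cytotoxicity

The source may hold more compounds than are shown below. What is called first, only, known or untested is meant among the compounds shown, and "the series" means these compounds.

Compound 1 `CC(C)NC(=N)c1ccc2cc(-c3cccc(OCCCOc4ccccc4)c3)oc2c1` is the weaker of the two measured inhibitors in an ADME assay on L6 cells (Rattus norvegicus) for cytotoxicity, read by resazurin assay, with a stated time of 70 h; a higher number here means a weaker inhibitor, a lower number a stronger inhibitor: compound 1 gives 82300 nM. Compound 2 `c1ccc(OCCCOc2cccc(-c3cc4ccc(C5=NCCN5)cc4o3)c2)cc1` gives 10100 nM in this assay. For the measured compounds named here, the only measured step, an 8.1-fold lower number from compound 1 to compound 2 (0.91 log units; beyond the scatter), exchanges the amidine-bearing end of the core and leaves the phenoxypropoxy side untouched.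

Compound 3 `CC(C)NC(=N)c1ccc2cc(-c3cccc(OCCCCOc4ccccc4)c3)oc2c1` differs from compound 1 at the opposite end: phenoxymethyl in place of phenoxy on a saturated chain carbon, three bonds along the chain from an oxygen on an aromatic ring. Read one bond further out, the same change is 3-phenoxypropyl to 4-phenoxybutyl. Going by the values given here, no measured pair in this assay changes this chain, so the step from compound 1 to compound 2 does not bear on it and there is no direct precedent for its size or direction.

With nothing in the measured compounds pointing either way, compound 3 is expected to sit close to compound 1, with a step of a 1.0-fold lower number from compound 1 to compound 3 (0.01 log units; within the scatter) that stays within the scatter. The estimate for compound 3 in this assay is therefore 80000 nM, with a range from 35000 nM to 180000 nM.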

Compound 3, half-maximal inhibitory concentration: 46500 nM
Compound 3: middle estimate off by 1.7-fold (0.24 log units), on the high side; the measured number falls inside the stated range.
By their numbers in this assay, from the lowest: compound 2; then compounds 3 and 1 (each within the scatter of the next).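

For the compounds shown here, this is the first reading at this position: in this assay, replacing phenoxy with phenoxymethyl on a saturated chain carbon, three bonds along the chain from an oxygen on an aromatic ring, gives a 1.8-fold lower number from compound 1 to compound 3 (0.25 log units; within the scatter). Read one bond further out, 3-phenoxypropyl to 4-phenoxybutyl is therefore a change that this pair cannot tell apart from repeat measurement, whereas the only earlier step, at the opposite end of the molecule, is an 8.1-fold lower number from compound 1 to compound 2 (0.91 log units; beyond the scatter). Nothing available explains the behaviour of the chain at this position, and no supporting data bear on the result.

The compounds shown leave open whether the same extension would stay within the scatter with the five-membered ring of compound 2 in place of the group it replaced in compound 1. They also leave open how a shorter 2-phenoxyethyl chain, a longer 5-phenoxypentyl chain, or an amine or a carboxylic acid in place of the terminal phenoxy would read in this assay.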